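The source may report more compounds than this note shows. Statements on the series, on what has been measured and on what is new or still open speak of the compounds shown alone.

Three measured compounds share one core. In a functional assay on DU-145 cells (Homo sapiens) for inhibition, read by sulforhodamine B assay, with a stated time of 48 h (on this read-out higher numbers stand for lower toxicity in this test and lower numbers for higher toxicity in this test), compound 1 `COc1ccc(-c2cc(/C=C/C(=O)c3ccc(N)cc3)[nH]n2)cc1` gives 9110 nM, compound 2 `COc1cc(-c2cc(/C=C/C(=O)c3ccc(N)cc3)[nH]n2)cc(OC)c1OC` gives 9950 nM, and compound 3 `COc1ccc(C(=O)/C=C/c2cc(-c3cc(OC)c(OC)c(OC)c3)n[nH]2)cc1OC` gives 4760 nM. Compound 2 lies within the scatter of compound 1, while the move to compound 3 is a 2.1-fold lower number from compound 2 to compound 3 (0.32 log units; beyond the scatter). Compound 4 `COc1ccc(-c2cc(/C=C/C(=O)c3ccc(N)cc3)[nH]n2)cc1OC` differs from compound 2 by hydrogen in place of methoxy on an aromatic carbon. Within the data shown here, no measured step removes a methoxy group at that position, so the only guide is that compound 2 differs solely in how many methoxy groups it carries from compound 1, which in this assay gives 9110 nM. That value lies within the scatter of compound 2. No step beyond the scatter is therefore expected, a 1.0-fold lower number from compound 2 to compound 4 (0.02 log units; within the scatter). The estimate for compound 4 in this assay is 9500 nM, in the range 5000 nM to 18000 nM.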

Compound 4, concentration lethal to 50% of the cells: 36800 nM
Beside the measured number, compound 4's estimate is 3.9-fold (0.59 log units) below it; measured number outside the range, above it.
By their numbers in this assay, from the lowest: compounds 3, 1 and 2 (each within the scatter of the next, the first and the last beyond it); then compound 4.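

In this assay, the methoxy at this position does not act in one direction: taking it away gives a higher number (a 3.7-fold higher number from compound 2 to compound 4 (0.57 log units; beyond the scatter)), and putting it in gives one too (a 4.0-fold higher number from compound 1 to compound 4 (0.61 log units; beyond the scatter)). Compound 4 therefore stands above both of its neighbours, so the result of this change depends on which other methoxy groups are on the ring. Nothing at hand explains this.

On these data alone, it remains open whether a hydroxyl, a fluorine or an ethoxy group on this carbon would give a number nearer compound 4 or compound 2.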